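The compounds below may be only part of what the source reports. "The series", "measured", "known", "first", "only" and "open" are said of these compounds alone.

Values from a functional assay on cells (KATO III cell, Homo sapiens) for antiproliferative activity, read by MTT assay (a higher number here means a weaker inhibitor, a lower number a stronger inhibitor), follow
Compound 1 `O=C1NC(c2ccccc2)CN1S(=O)(=O)c1ccc2c(c1)CCCN2` gives > 20000 nM as a limit, not a number
Compound 2 `CCOC(=O)N1CCCc2cc(S(=O)(=O)N3CC(c4ccccc4)NC3=O)ccc21` gives 11200 nM in the same read-out
Compound 3 `CCCOC(=O)N1CCCc2cc(S(=O)(=O)N3CC(c4ccccc4)NC3=O)ccc21` gives 3300 nM in the same read-out
Compound 4 `O=C(c1ccccc1)N1CCCc2cc(S(=O)(=O)N3CC(c4ccccc4)NC3=O)ccc21` has no value yet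

Among the actual numbers, compound 3 is lowest at 3300 nM in this series. Compound 4 carries phenyl in place of propoxy on a carbonyl carbon as its change: phenyl in place of propoxy on a carbonyl carbon, or propoxycarbonyl to benzoyl. The closest guide is a 3.4-fold lower number from compound 2 to compound 3 (0.53 log units; beyond the scatter) for a change within that group. Adding the group gave an at least 6.0-fold lower number from compound 1 to compound 3 (0.78 log units; beyond the scatter) as a second guide. The step of an at least 1.7-fold lower number from compound 1 to compound 2 (0.25 log units; that floor lies within the scatter) has a floor within the scatter. No ring on this carbonyl has been measured, so the direction remains uncertain. A modest step to a lower number is expected, a 2.2-fold lower number from compound 3 to compound 4 (0.34 log units; beyond the scatter) being the estimated change. For compound 4 the estimated value is 1500 nM with 350 nM to 6000 nM as the expected range.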

Compound 4, half-maximal inhibitory concentration: 14300 nM
Beside the measured number, compound 4's estimate is 9.5-fold (0.98 log units) below it; measured number above the stated range.
By their numbers in this assay, from the lowest: compound 3; then compounds 2 and 4 (each within the scatter of the next). At a limit, above all of these: compound 1.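

In this assay, phenyl in place of propoxy on this carbonyl carbon reverses the gain seen on going from ethoxy to propoxy: a 4.3-fold higher number from compound 3 to compound 4 (0.64 log units; beyond the scatter). Phenyl in place of ethoxy gives a 1.3-fold higher number from compound 2 to compound 4 (0.11 log units; within the scatter), so benzoyl does not separate from ethoxycarbonyl. Benzoyl in place of hydrogen gives an at least 1.3-fold lower number from compound 1 to compound 4 (0.14 log units; that floor lies within the scatter), and this step is only a floor: the limit of > 20000 nM in this assay, at which 1 of the 4 values shown sits.

Going by these compounds, whether the loss follows from the ring or from the missing oxygen remains open. Benzyloxy, butoxy or an amine on this carbonyl carbon would help separate these readings.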